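Bromo to hydrogen: from compound 3 to compound 4

This account rests on a few compounds, and the source may have more. Where it says the series, first, only, none or still open, it means among the compounds named here.

Three analogues on a shared core have been measured in a functional assay on HeLa cells (Homo sapiens) for antiproliferative activity, read by MTT assay, with a stated time of 24 h; a higher number here means a weaker inhibitor, a lower number a stronger inhibitor. Compound 1 `COC(=O)c1scc(-c2ccc(NC(=O)c3ccc(OC)nc3)cc2)c1OC` gives 24400 nM. Compound 2 `COC(=O)c1scc(-c2ccc(NC(=O)c3ccc(F)c(Cl)n3)cc2)c1OC` gives 16200 nM, and compound 3 `COC(=O)c1scc(-c2ccc(NC(=O)c3ccc(C(F)(F)F)cc3Br)cc2)c1OC` gives 16200 nM. Among the compounds with values here, the only single-point step measured so far is a 1.5-fold lower number from compound 1 to compound 2 (0.18 log units; within the scatter), with 6-chloro-5-fluoropyridin-2-yl in place of 6-methoxypyridin-3-yl on a carbonyl carbon. Compound 3 stands level with compound 2 at the digits reported, the pair sharing the lowest number of the three, and compound 1 sits within the scatter of both. Compound 4 `COC(=O)c1scc(-c2ccc(NC(=O)c3ccc(C(F)(F)F)cc3)cc2)c1OC` differs from compound 3 in one place: hydrogen in place of bromo on an aromatic carbon. Within the data shown here, no measured pair isolates a bromo substituent, so no step in this set bears directly on the change. Among the measured compounds shown here, the one step that is available, a 1.5-fold lower number from compound 1 to compound 2 (0.18 log units; within the scatter), swapped the whole group on the carbonyl carbon and still stayed within the scatter, and all three numbers cluster tightly. The expectation for this assay is therefore no movement beyond the scatter, an expected step of a 1.0-fold lower number from compound 3 to compound 4 (0.01 log units; within the scatter). Compound 4 is estimated at 16000 nM, with a range from 7000 nM to 36000 nM.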

Compound 4, half-maximal inhibitory concentration: 14400 nM
Beside the measured number, compound 4's estimate is 1.1-fold (0.05 log units) above it; the measured number falls inside the stated range.
By their numbers in this assay, from the lowest: compounds 4, 2, 3 and 1 (each within the scatter of the next).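

In this assay, within the data shown here, the only pair that isolates this position gives (a 1.1-fold lower number from compound 3 to compound 4 (0.05 log units; within the scatter)), so at this aromatic carbon, ortho to a large group and meta to a trifluoromethyl group, bromo and hydrogen cannot be told apart beyond the scatter. Compound 4 also adds two comparisons of the whole group on the carbonyl carbon, with 4-(trifluoromethyl)phenyl in place of 6-chloro-5-fluoropyridin-2-yl (a 1.1-fold lower number from compound 2 to compound 4 (0.05 log units; within the scatter)) and in place of 6-methoxypyridin-3-yl (a 1.7-fold lower number from compound 1 to compound 4 (0.23 log units; within the scatter)), and both steps stay within the scatter, so no group exchange shown so far separates any compounds in this series. No measurement on hand explains this flat picture, and no property can be assigned to the bromo or to the hydrogen.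

From the compounds shown here alone, whether an amine or a carboxylic acid on this same aromatic carbon would give a step beyond the scatter stays open. Also open, going by these compounds, is whether a nitrile in place of the trifluoromethyl group would do so, and whether any of these readings would hold outside this assay.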